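The source may report more compounds than this note shows. Statements on the series, on what has been measured and on what is new or still open speak of the compounds shown alone.

Compound 2 `CC(NC(=O)CN)C(=O)N(C)c1ccc(Cl)cc1C(=O)c1ccccc1Cl`: 0.47 mg/kg
Compound 1 `NCC(=O)NCC(=O)Nc1ccc([N+](=O)[O-])cc1C(=O)c1ccccc1`: 4.82 mg/kg
Compound 3 `CN(C(=O)CNC(=O)c1ccccc1)c1ccc(Cl)cc1C(=O)c1ccccc1`: 7.6 mg/kg

In a functional assay on the whole organism for antagonist activity, with Mus musculus as the target (a lower number here means that less compound is needed, a higher number that more compound is needed for the effect), compound 2 gives the lowest of the three numbers. Compound 1 stands higher, beyond the scatter, and compound 3 stands higher still, also beyond the scatter. The next compound, compound 4 `CCCCC(=O)NCC(=O)N(C)c1ccc(Cl)cc1C(=O)c1ccccc1Cl`, keeps the core of compound 2 and alters only the chain on the amide. The change is ((butylcarbonyl)amino)methyl in place of 1-(((aminomethyl)carbonyl)amino)ethyl on a carbonyl carbon. Among the compounds with values here, no pair of measured compounds separated by a single change is available, so the direction must be judged from the spread of the three values. Because compound 3, which also carries an acyl group on the glycine nitrogen, gives 7.6 mg/kg, a rise in the number is expected. The expected step is a 4.3-fold higher number from compound 2 to compound 4 (0.63 log units; beyond the scatter), beyond the scatter. For compound 4 the estimate in this assay is 2 mg/kg, within 0.6 mg/kg to 7 mg/kg.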

Compound 4, dose for half-maximal effect: 1.3 mg/kg
Compound 4: middle estimate off by 1.5-fold (0.19 log units), on the high side, and the stated range covers the measured number.
By their numbers in this assay, from the lowest: compound 2; then compound 4; then compounds 1 and 3 (each within the scatter of the next).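

In this assay, within the data shown here, the exchange of 1-(((aminomethyl)carbonyl)amino)ethyl for ((butylcarbonyl)amino)methyl on a carbonyl carbon gives a 2.8-fold higher number from compound 2 to compound 4 (0.44 log units; beyond the scatter), the first step that can be read at a single place. The position thus accepts a chain without the terminal amine at only a modest rise in the dose needed. Nothing measured here gives a reason for this step. Going by these compounds, the change removes the amine and the methyl branch together, so their separate shares remain unknown. On these data alone, whether a carboxylic acid or a longer chain here would keep the number low also remains open.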